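Shifting the amino group in compound 1

This account rests on a few compounds, and the source may have more. Where it says the series, first, only, none or still open, it means among the compounds named here.

Compound 1 `COc1cc(-c2ncnn2-c2cccc(N)c2)cc(OC)c1OC` gives > 10000 nM
Compound 2 `COc1cccc(-c2ncnn2-c2cc(OC)c(OC)c(OC)c2)c1` gives > 10000 nM
Compound 3 `CCOc1ccc(-c2ncnn2-c2cc(OC)c(OC)c(OC)c2)cc1Cl` gives 20 nM

In a functional assay on K562 cells (Homo sapiens) for antiproliferative activity, read by MTT assay, with a stated time of 72 h (a higher number here means a weaker inhibitor, a lower number a stronger inhibitor), compound 1 gives > 10000 nM as a limit of the assay, not a number. Compound 2 gives > 10000 nM in this assay as a limit too. Compound 1 thus stands at the limit of > 10000 nM in this assay, at which 2 of the 3 values shown sit, and has no exact value. Compound 3 gives 20 nM as a true measured number.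

Compound 4 (`COc1cc(-c2ncnn2-c2ccc(N)cc2)cc(OC)c1OC`) has the same atoms as compound 1, joined differently, with 4-aminophenyl in place of 3-aminophenyl on an aromatic nitrogen is the whole change. For the measured compounds named here, no two measured compounds differ in just one place. A move toward stronger inhibition is expected, of uncertain size, because compound 3 gives 20 nM and shows that this family can inhibit strongly. Compound 4 may still stay at the limit. The expected change is an at least 3.3-fold lower number from compound 1 to compound 4 (0.52 log units; beyond the scatter) and remains only an estimate. Compound 4 is expected at 3000 nM within an estimated range from 200 nM to 10000 nM.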

Compound 4, half-maximal inhibitory concentration: > 10000 nM
Compound 4: only a limit was reported (the forecaster's own chance of this, stated with the estimate: 45%); middle value at least 3.3-fold (0.52 log units) away from the limit.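

In this assay compound 4 gives > 10000 nM as a limit of the assay, not a number. For the compounds shown here, compound 1 stands at that same limit, so no step between compound 1 and compound 4 can be read: the limit of > 10000 nM in this assay, at which 3 of the 4 values shown sit. From the compounds shown here alone, whether 3-aminophenyl and 4-aminophenyl differ in strength at all stays open.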